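Moving the benzyl fluorine: compound 2 to compound 3

A few compounds are considered here, and "the series" means these few. Any claim that something is new, unique, unknown or untested is made for them only; others in the source may bear on it.

In a functional assay on MCF7 cells (Homo sapiens) for cytotoxicity, read by MTT assay, with a stated time of 24 h (a higher number here means a weaker inhibitor, a lower number a stronger inhibitor), compound 2 (`O=C1/C(=C/c2ccccc2F)CN(C(=S)SCc2cn(Cc3ccccc3F)nn2)C/C1=C\c1ccccc1F`) gives 51600 nM. Within the data shown here, compound 1 (`O=C1/C(=C/c2ccccc2F)CN(C(=S)SCc2cn(Cc3ccccc3Cl)nn2)C/C1=C\c1ccccc1F`) gives 78700 nM, and these are the only two measured values, lying within the scatter of each other. The next structure is compound 3 (`O=C1/C(=C/c2ccccc2F)CN(C(=S)SCc2cn(Cc3ccc(F)cc3)nn2)C/C1=C\c1ccccc1F`), which has the same atoms as compound 2, joined differently: 4-fluorophenyl in place of 2-fluorophenyl on a saturated chain carbon bound to an aromatic nitrogen. Cut one bond further out, this reads 2-fluorobenzyl to 4-fluorobenzyl.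

Among the measured compounds shown here, the one measured step, fluoro in place of chloro on an aromatic carbon, is a 1.5-fold lower number from compound 1 to compound 2 (0.18 log units; within the scatter). For the measured compounds named here, it bears on the same group but is a different change, and no measured compound carries the 4-fluorophenyl group. Going by the values given here, the data therefore hold no direct precedent for this change. Among the compounds with values here, with only that small step as a guide, no shift beyond the scatter is expected in this assay, in either direction. The estimated change is a 1.0-fold lower number from compound 2 to compound 3 (0.01 log units; within the scatter). For compound 3 the expected value is 50000 nM, with an estimated range from 24000 nM to 100000 nM.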

Compound 3, half-maximal inhibitory concentration: 56900 nM
The estimate for compound 3 lay 1.1-fold (0.06 log units) below the measured number; the measured number falls inside the stated range.
By their numbers in this assay, from the lowest: compounds 2, 3 and 1 (each within the scatter of the next).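

In this assay, among these compounds, going from 2-fluorobenzyl to 4-fluorobenzyl gives the first reading on where the fluorine sits in this group, rather than on which halogen it carries (a 1.1-fold higher number from compound 2 to compound 3 (0.04 log units; within the scatter)). The change from 2-chlorophenyl to 4-fluorophenyl on the same saturated chain carbon bound to an aromatic nitrogen gives a matching result (a 1.4-fold lower number from compound 1 to compound 3 (0.14 log units; within the scatter)), so all three pairs among compound 1, compound 2 and compound 3 now lie within the scatter, and neither the halogen swap nor the relocated fluorine separates these compounds in this cytotoxicity read-out. No measurement shown bears on why this group tolerates these changes without a shift beyond the scatter.

All three compounds carry a single halogen on this phenyl ring and the same core, so the reading says nothing about a benzyl group bearing an amine or a carboxylic acid, or about a longer chain in place of the benzyl group. As far as these compounds go, whether any such group would move the number beyond the scatter stays open, as does whether the 2-fluorophenyl groups on the shared core are equally tolerant of change.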